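From 1,2,3-Thiadiazol-4-yl to 2-Methylpyridin-3-yl on the Amide

The compounds below may be only part of what the source reports. "The series", "measured", "known", "first", "only" and "open" are said of these compounds alone.

Compound 1 `O=C(NC1CCCCC1)NS(=O)(=O)N1CCC(CCNC(=O)c2cscn2)CC1` gives 23% in a functional assay on the whole organism (blood) with Rattus norvegicus as the target, with stated times of 24 h and 1 h, at a dose of 5 mg/kg by the intraperitoneal route; on this read-out lower numbers stand for a weaker effect and higher numbers for a stronger effect at the one dose given. Going by the values given here, compound 2 `O=C(NC1CCCCC1)NS(=O)(=O)N1CCC(CCNC(=O)c2csnn2)CC1` gives 19% in this assay; the step of a number 4 percentage points lower from compound 1 to compound 2 (within the scatter) leaves the two compounds within the scatter of each other, so compound 2 stands at no real distance from compound 1 among only two numbers. Compound 3 `Cc1ncccc1C(=O)NCCC1CCN(S(=O)(=O)NC(=O)NC2CCCCC2)CC1` differs from compound 2 in one place: 2-methylpyridin-3-yl in place of 1,2,3-thiadiazol-4-yl on a carbonyl carbon. Among the compounds with values here, the only measured step that bears on this change is the ring exchange at the same carbonyl carbon, which stayed within the scatter, and no step beyond the scatter is therefore expected: the step is estimated as a number 1 percentage points higher from compound 2 to compound 3 (within the scatter). Compound 3 is expected to give 20% in this assay, with a range from 5% to 38%.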

Compound 3, a percentage reported as activity, at one dose (the size of the read-out at that dose, not a potency): 16%
Compound 3: the middle estimate sits 4 percentage points above what was measured; measured number inside the range.
By their numbers in this assay, from the lowest: compounds 3, 2 and 1 (each within the scatter of the next).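

In this assay, the place on the carbonyl carbon also accepts a six-membered aromatic ring, 2-methylpyridin-3-yl, with a number 3 percentage points lower from compound 2 to compound 3 (within the scatter) and a number 7 percentage points lower from compound 1 to compound 3 (within the scatter). Changing ring size and hetero atom count therefore produced no step beyond the scatter among these three compounds. No available measurement explains this insensitivity. From the compounds shown here alone, it remains open whether any group at this place can move the read-out beyond the scatter, for instance a phenyl ring carrying a carboxylic acid or an amine.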